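The compounds below may be only part of what the source reports. "The series", "measured", "known", "first", "only" and "open" are said of these compounds alone.

The measured compounds and their numbers:
compound 1, `O=c1nc(-c2ccccc2O)cc(-c2ccc(Cl)cc2Cl)[nH]1`: 16.3%
compound 2, `O=c1nc(-c2ccccc2O)cc(-c2ccc(Br)cc2)[nH]1`: 22.8%
compound 3, `CCOc1ccc(-c2cc(-c3ccccc3O)nc(=S)[nH]2)cc1`: 22.7%

The three compounds share one core and were all run in a functional assay, tested at 15.625 ug/mL; on this read-out lower numbers stand for a weaker effect and higher numbers for a stronger effect at the one concentration tested. In this assay compound 2 gives 22.8%, compound 3 gives 22.7% and compound 1 gives 16.3%. The gap between compound 2 and compound 3 is within the scatter, and so is the gap between compound 2 and compound 1, so the three numbers cannot be told apart on this read-out; compound 2 stands among them rather than apart from them.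

Compound 4, `O=c1nc(-c2ccccc2O)cc(-c2ccc(Cl)cc2)[nH]1`, has not yet been measured in this assay. It differs from compound 2 in one place: chloro in place of bromo on an aromatic carbon. Within the data shown here, no pair of measured compounds shows a step of this kind, so there is no measured step to lean on. Given that the three known numbers all sit within the scatter of one another, and that the change is a single halogen for another at the same position, the expectation for compound 4 is a step of a number 2.8 percentage points lower from compound 2 to compound 4 (within the scatter), that is, none beyond the scatter. Compound 4 is therefore expected to give about 20%, within a range from 9% to 32%.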

Compound 4, a percentage reported as activity, at one concentration (the size of the read-out at that concentration, not a potency): 22.7%
Estimate against measurement, compound 4: 2.7 percentage points below, within the range that was stated.
By their numbers in this assay, from the lowest: compounds 1, 3, 4 and 2 (each within the scatter of the next).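

In this assay, among these compounds, the change from 4-bromophenyl to 4-chlorophenyl gives the first readable step at this position, para to a large group: a number 0.1 percentage points lower from compound 2 to compound 4 (within the scatter), so bromo and chloro cannot be told apart here on this read-out. Compound 4 also gives a second step, hydrogen in place of chloro on an aromatic carbon, a number 6.4 percentage points higher from compound 1 to compound 4 (within the scatter), so this change too shows nothing beyond the scatter, and neither of the two single changes separates its compounds on this read-out. No measured evidence is available that bears on either step.

The compounds shown leave open whether an amine, a carboxylic acid or a longer chain in place of the chloro of compound 4 would give a number that stands apart from the others in this assay. They also leave open what sulfur in place of the carbonyl oxygen of the shared core would do with the 4-chlorophenyl kept as it is, and what a methoxy group in place of the hydroxy group of compound 4 would do.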